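Methoxy Replaced by Nitro: A Step Without Precedent

The source may hold more compounds than are shown below. What is called first, only, known or untested is meant among the compounds shown, and "the series" means these compounds.

Among the compounds with values here, compound 1 `COc1ccc(C(=O)/C=C/c2ccc(OCc3cn(Cc4ccc(Br)cc4)nn3)cc2)cc1` gives 53% in a functional assay on MCF7 cells (Homo sapiens) for inhibition, read by MTT assay, with a stated time of 48 h, tested at 10 uM (on this read-out lower numbers stand for less inhibition of growth and higher numbers for more inhibition of growth at the one concentration tested), the highest of the three numbers measured so far. Compound 2 `COc1ccc(C(=O)/C=C/c2ccc(OCc3cn(Cc4ccccc4F)nn3)cc2)cc1` gives 32% in this assay, and compound 3 `COc1ccc(C(=O)/C=C/c2ccc(OCc3cn(Cc4cccc(F)c4)nn3)cc2)cc1` gives 41%. Within the data shown here, all the measured steps concern the group on the saturated chain carbon bound to the aromatic nitrogen: a number 21 percentage points lower from compound 1 to compound 2 (beyond the scatter) and a number 12 percentage points lower from compound 1 to compound 3 (beyond the scatter), while a number 9 percentage points higher from compound 2 to compound 3 (within the scatter). Compound 4 `O=C(/C=C/c1ccc(OCc2cn(Cc3ccc(Br)cc3)nn2)cc1)c1ccc([N+](=O)[O-])cc1` differs from compound 1 at a different place on the shared core: nitro in place of methoxy on an aromatic carbon. Among the measured compounds shown here, none of the measured steps touches this part of the molecule, so the measured series gives no indication of which direction the number should move, nor by how much. In the absence of any bearing step, the step of no change at the digits printed from compound 1 to compound 4 (within the scatter) is expected to stay within the scatter, though with little confidence. Compound 4 is estimated at 53%, with a broad range from 25% to 78% that allows for an unknown effect of the change.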

Compound 4, percent growth inhibition at one concentration: 18%
The estimate for compound 4 lay 35 percentage points above the measured number, outside the stated range (below it).
By their numbers in this assay, from the lowest: compound 4; then compounds 2 and 3 (each within the scatter of the next); then compound 1.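

The aromatic carbon bearing methoxy in compound 1 proves to be a position that matters in this assay: nitro in place of methoxy gives a number 35 percentage points lower from compound 1 to compound 4 (beyond the scatter), a larger step than a number 21 percentage points lower from compound 1 to compound 2 (beyond the scatter) or a number 12 percentage points lower from compound 1 to compound 3 (beyond the scatter) at the saturated chain carbon. With the 4-bromophenyl group held constant, this single exchange of 4-methoxyphenyl for 4-nitrophenyl is enough to weaken growth inhibition markedly at the one concentration tested. Nothing measured here accounts for the fall in the number.

Whether the fall belongs to nitro itself or to the loss of methoxy remains open, as only these two groups are shown on this carbon, and an amine, a hydroxyl or a plain hydrogen there could separate the two readings. Also open, going by these compounds, is whether the step would be the same with 2-fluorophenyl or 3-fluorophenyl in place of 4-bromophenyl.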